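The source may hold more compounds than are shown below. What is called first, only, known or untested is meant among the compounds shown, and "the series" means these compounds.

Compounds 1 to 3 share one core and differ only in the halogen-bearing aromatic group on the side chain. In a functional assay on K562 cells (Homo sapiens) for antiproliferative activity, with a stated time of 72 h (a lower number here means a stronger inhibitor, a higher number a weaker inhibitor), compound 1 `OC[C@H]1O[C@@H](n2cnc3c(NCc4ccc(Br)cc4)ncnc32)[C@H](O)[C@@H]1O` gives 68200 nM, compound 2 `OC[C@H]1O[C@@H](n2cnc3c(NCc4ccc(Cl)cc4Cl)ncnc32)[C@H](O)[C@@H]1O` gives 106000 nM, and compound 3 `OC[C@H]1O[C@@H](n2cnc3c(NCc4ccc(F)cc4F)ncnc32)[C@H](O)[C@@H]1O` gives 9600 nM. Compound 3 therefore has the lowest number of the three and is the strongest inhibitor among them.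

Compound 4 `OC[C@H]1O[C@@H](n2cnc3c(NCc4ccc(F)cc4Cl)ncnc32)[C@H](O)[C@@H]1O` has not yet been measured. It turns the 2,4-difluorobenzyl group of compound 3 into 2-chloro-4-fluorobenzyl: chloro in place of fluoro on an aromatic carbon. The chloro enters on an aromatic carbon, ortho to a large group and meta to a fluoro group.

The closest guide is an 11-fold lower number from compound 2 to compound 3 (1.04 log units; beyond the scatter), which exchanges chloro for fluoro in two places at once. Among the measured compounds shown here, compound 4 reverses only one of those two exchanges, so a part of that step should come back, in the direction of a weaker inhibitor. The other two steps help less: a 7.1-fold lower number from compound 1 to compound 3 (0.85 log units; beyond the scatter) involves a bromo group, and a 1.6-fold higher number from compound 1 to compound 2 (0.19 log units; within the scatter) does the same. The data do not show how the larger step divides between the two places, so an even split is only an assumption. On that basis, the expected change is a 3.1-fold higher number from compound 3 to compound 4 (0.49 log units; beyond the scatter). In this assay, compound 4 is estimated at 30000 nM, with an expected range of 11000 nM to 90000 nM.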

Compound 4, half-maximal inhibitory concentration: 15600 nM
The estimate for compound 4 lay 1.9-fold (0.28 log units) above the measured number; low and high end bracket the measured number.
By their numbers in this assay, from the lowest: compounds 3 and 4 (each within the scatter of the next); then compounds 1 and 2 (each within the scatter of the next).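

In this assay, among the compounds shown here, this is the first compound to separate the two halogen exchanges that the step from compound 2 to compound 3 made at once. Chloro in place of fluoro on the aromatic carbon ortho to a large group, taken alone, gives a 1.6-fold higher number from compound 3 to compound 4 (0.21 log units; within the scatter), so at this position the exchange does not show up beyond the scatter. Most of the earlier gap instead goes with the other halogen: with the 2-chloro group kept, fluoro in place of chloro gives a 6.8-fold lower number from compound 2 to compound 4 (0.83 log units; beyond the scatter), and the 2-chloro-4-fluorophenyl group in place of 4-bromophenyl gives a 4.4-fold lower number from compound 1 to compound 4 (0.64 log units; beyond the scatter).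

As far as these compounds go, it remains open how a methyl or methoxy group would read at this same position, and whether 4-chloro-2-fluorobenzyl would give the same picture from the other side. No supporting measurement is available to explain why the two places differ in this way.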